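The source may report more compounds than this note shows. Statements on the series, on what has been measured and on what is new or still open speak of the compounds shown alone.

Going by the values given here, in a functional assay on PC-3 cells (Homo sapiens) for inhibition, read by sulforhodamine B assay, with a stated time of 48 h, tested at 50 uM (on this read-out higher numbers stand for more inhibition of growth at the one concentration tested and lower numbers for less inhibition of growth), compound 1 `CCOc1ccc([C@@H]2CC(=O)c3cc(CC=C(C)C)c(OC)cc3O2)cc1` gives 60% and compound 2 `C#CCOc1ccc([C@@H]2CC(=O)c3cc(CC=C(C)C)c(OC)cc3O2)cc1` gives 52%, so compound 2 stands within the scatter of its only measured neighbour. Compound 3 `COc1cc2c(cc1CC=C(C)C)C(=O)C[C@@H](c1ccc(Oc3ccc(Br)cc3)cc1)O2` differs from compound 2 by 4-bromophenyl in place of propargyl on an oxygen on an aromatic ring, which is 4-bromophenyl in place of propargyl on an oxygen on an aromatic ring. Among the compounds with values here, the only measured step that bears on this is a number 8 percentage points lower from compound 1 to compound 2 (within the scatter), and no measured compound carries the entering ring. No change beyond the scatter is therefore expected, and the estimated step is a number 6 percentage points higher from compound 2 to compound 3 (within the scatter). For compound 3 the estimate is 58%, with an expected range of 35% to 80%.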

Compound 3, percent growth inhibition at one concentration: 55%
The estimate for compound 3 lay 3 percentage points above the measured number; low and high end bracket the measured number.
By their numbers in this assay, from the lowest: compounds 2, 3 and 1 (each within the scatter of the next).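

In this assay this oxygen on an aromatic ring carries an aromatic ring as readily as a short chain: 4-bromophenyl in place of propargyl gives a number 3 percentage points higher from compound 2 to compound 3 (within the scatter), and 4-bromophenyl in place of ethyl gives a number 5 percentage points lower from compound 1 to compound 3 (within the scatter). Ethyl, propargyl and 4-bromophenyl are thus not told apart at the one concentration tested. Nothing available explains this lack of separation.

On these data alone, whether an amine or a carboxylic acid on this oxygen would move the number beyond the scatter remains open. So does whether the phenyl ring needs its bromine.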